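The source may hold more compounds than are shown below. What is called first, only, known or untested is meant among the compounds shown, and "the series" means these compounds.

Compound 1, `COc1ccc(C(=O)c2cc(OC)c(OC)c(OC)c2)cc1NC(=O)/C=C/c1ccc(OC)c(OC)c1`, gives 10200 nM in a functional assay on DU-145 cells (Homo sapiens) for cytotoxicity, read by MTT assay, with a stated time of 72 h; a higher number here means a weaker inhibitor, a lower number a stronger inhibitor.
Compound 2, `COc1cccc(/C=C/C(=O)Nc2cc(C(=O)c3cc(OC)c(OC)c(OC)c3)ccc2OC)c1`, gives 6200 nM in this assay.

Among the measured compounds shown here, compound 2 is one of only two compounds measured, and the single comparison available, a 1.6-fold lower number from compound 1 to compound 2 (0.22 log units; within the scatter), lies within the scatter, so the two compounds cannot be told apart on these numbers. Compound 3, `C#CCOc1cccc(/C=C/C(=O)Nc2cc(C(=O)c3cc(OC)c(OC)c(OC)c3)ccc2OC)c1`, carries ethynyl in place of hydrogen on a saturated chain carbon bound to an oxygen on an aromatic ring; the methoxy of compound 2 thus becomes propargyloxy. For the measured compounds named here, no measured step touches this kind of change: the one step known, a 1.6-fold lower number from compound 1 to compound 2 (0.22 log units; within the scatter), concerns removal of a methoxy group, not its extension, and was itself small. With nothing pointing either way, the expectation for compound 3 is a step of a 1.2-fold lower number from compound 2 to compound 3 (0.09 log units; within the scatter), meaning no change beyond the scatter. Compound 3 is therefore estimated at 5000 nM, within a range of 2000 nM to 14000 nM.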

Compound 3, half-maximal inhibitory concentration: 15800 nM
Compound 3: the middle estimate sits 3.2-fold (0.50 log units) below what was measured; measured number outside the range, above it.
By their numbers in this assay, from the lowest: compounds 2, 1 and 3 (each within the scatter of the next, the first and the last beyond it).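

Going from methoxy to propargyloxy on the shared core gives the first change here that lies beyond the scatter (a 2.5-fold higher number from compound 2 to compound 3 (0.41 log units; beyond the scatter)), so the group on this oxygen can matter, if only modestly, in this assay. Set against the 3,4-dimethoxyphenyl compound, the 3-(propargyloxy)phenyl compound cannot be told apart (a 1.5-fold higher number from compound 1 to compound 3 (0.19 log units; within the scatter)), so the step is visible only against compound 2. Nothing measured here says why the number rose.

The compounds shown leave open whether the rise goes with the triple bond itself or simply with a longer chain on this oxygen, which a propyl group in place of propargyl would help to separate. They also leave open how a chain ending in an amine would read at this place.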